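Imidazole-to-pyridine swap on the amide-bearing carbon

The source may hold more compounds than are shown below. What is called first, only, known or untested is meant among the compounds shown, and "the series" means these compounds.

Measured so far:
compound 1 `O=C(C1CCCCN1C(=O)CC1CCN(Cc2ccn(-c3ccc(C(F)(F)F)cc3)c2)CC1)N1CCCC1` — 66 nM
compound 2 `O=C(CC1CCN(Cc2ccn(-c3ccc(C(F)(F)F)cc3)c2)CC1)NC(c1ccccc1)c1cnc[nH]1` — 17 nM

In an assay on HEK293 cells for displacement of a labelled ligand from melanin-concentrating hormone receptor 1 (Homo sapiens) (a higher number here means a weaker inhibitor, a lower number a stronger inhibitor), compound 2 gives 17 nM, the lower of the two numbers; compound 1 at 66 nM sits beyond the scatter above it. The two differ in more than one place, so the gap cannot be tied to a single change.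

Compound 3 `O=C(CC1CCN(Cc2ccn(-c3ccc(C(F)(F)F)cc3)c2)CC1)NC(c1ccccc1)c1ccccn1` is not yet measured. It carries pyridin-2-yl in place of 1H-imidazol-5-yl on a saturated chain carbon bound to an amide-type nitrogen and an aromatic carbon; the hydrogen-bond donor of the five-membered ring is lost, the acceptor count is unchanged. For the measured compounds named here, no comparable step exists among the measured pairs, so direction rests on the change alone. A modest weakening is expected, though a shift within the scatter would not surprise. For compound 3 the estimate in this assay is 35 nM (range 10 nM to 120 nM), a step of a 2.1-fold higher number from compound 2 to compound 3 (0.31 log units; beyond the scatter) expected from compound 2 to compound 3.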

Compound 3, half-maximal inhibitory concentration: 41 nM
For compound 3 the middle estimate is 1.2-fold (0.07 log units) below the measured one; the measured number falls inside the stated range.
By their numbers in this assay, from the lowest: compound 2; then compounds 3 and 1 (each within the scatter of the next).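

In this assay, for the compounds shown here, pyridin-2-yl in place of 1H-imidazol-5-yl on a saturated chain carbon bound to an amide-type nitrogen and an aromatic carbon gives a 2.4-fold higher number from compound 2 to compound 3 (0.38 log units; beyond the scatter) as the first single-place step, a modest one. This position therefore accepts a six-membered aromatic ring lacking a hydrogen-bond donor, at a measurable cost. Nothing at hand accounts for the step, and the ring size and the donor change cannot be separated. Still open, on these data alone, is whether 1-methylimidazol-5-yl or pyridin-3-yl on this carbon would give a number nearer that of compound 2 or that of compound 3.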